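Adding a Second Chloro to the Fused Core

The compounds below may be only part of what the source reports. "The series", "measured", "known", "first", "only" and "open" are said of these compounds alone.

In a functional assay on NCI-H23 cells (Homo sapiens) for cytotoxicity, read by sulforhodamine B assay, with a stated time of 48 h (a higher number here means a weaker inhibitor of growth, a lower number a stronger inhibitor of growth), two compounds have been measured so far. Compound 1 `ClCc1ccccc1Cn1cnc2c(Cl)nc(Cl)nc21` gives 3090 nM. Compound 2 `ClCc1cccc(Cn2cnc3ncnc(Cl)c32)c1` gives 3380 nM, and the two numbers lie within the scatter of each other, so no order between them can be read from these data.

Compound 3 `ClCc1cccc(Cn2cnc3nc(Cl)nc(Cl)c32)c1` has not yet been measured in this assay. It differs from compound 2 in one place: chloro in place of hydrogen on an aromatic carbon, in words, chloro in place of hydrogen on an aromatic carbon, sitting between two ring nitrogen atoms of the fused core. Among the measured compounds shown here, no measured pair showing this exact change is available, so its effect in this assay can only be guessed. The closest hint is that compound 1 already carries a chloro on the corresponding carbon and gives 3090 nM, a number close to that of compound 2.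

On this basis compound 3 is expected to give about 2800 nM, with a likely range from 1200 nM to 6500 nM. The step of a 1.2-fold lower number from compound 2 to compound 3 (0.08 log units; within the scatter) is therefore expected to stay within the scatter.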

Compound 3, concentration for total growth inhibition: 30900 nM
Compound 3: the middle estimate sits 11-fold (1.04 log units) below what was measured, outside the stated range (above it).
By their numbers in this assay, from the lowest: compounds 1 and 2 (each within the scatter of the next); then compound 3.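

The chloro on the aromatic carbon between two ring nitrogen atoms is not a silent addition in this assay and gives a 9.1-fold higher number from compound 2 to compound 3 (0.96 log units; beyond the scatter) so that a single added heavy atom at this position clearly weakens growth inhibition. Among the compounds shown here, this is the first direct reading of the change, since no earlier pair differed only here; compound 1 also carries a chloro on this carbon, but it differs from compound 3 in other places as well, so it cannot isolate this step. Nothing measured here bears on why the number rises, and the reason remains unknown.

As far as these compounds go, it remains open whether this loss is specific to chloro or would also appear with another group on the same carbon, such as an amine, a methoxy group or a methyl group. From the compounds shown here alone, it is also open whether the chloro has the same effect when the chloromethyl group and the rest of the molecule are arranged as in compound 1, which would need a partner lacking only that chloro.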